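Carbamoyl for phenyl on the compound at the limit

The source may hold more compounds than are shown below. What is called first, only, known or untested is meant among the compounds shown, and "the series" means these compounds.

In an ADME assay on HeLa cells (Homo sapiens) for cytotoxicity, read by crystal violet staining, with a stated time of 72 h (a lower number here means that less compound is tolerated, a higher number that more compound is tolerated), compound 1 (`Cc1cc(-c2noc(C(F)(F)F)n2)cc(C)c1OCCCc1cc(C(=O)OC(C)C)no1`) gives 17900 nM as a measured number. Compound 2 (`Cc1cc(-c2noc(C(F)(F)F)n2)cc(C)c1OCCCc1cc(-c2ccccc2)no1`) gives > 100000 nM here, and that is a limit of the assay, not a number. Compound 3 (`Cc1cc(-c2noc(C(F)(F)F)n2)cc(C)c1OCCCc1cc(C(N)=O)no1`) has carbamoyl in place of phenyl on an aromatic carbon. For the measured compounds named here, the one measured step at this place is an at least 5.5-fold higher number from compound 1 to compound 2 (0.74 log units; beyond the scatter) and it ran towards phenyl, so a lower number of similar or smaller size is expected in this assay once phenyl leaves. The expected step is an at least 3.3-fold lower number from compound 2 to compound 3 (0.52 log units; beyond the scatter) in all. For compound 3 the estimated value is 30000 nM (range 10000 nM to 100000 nM).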

Compound 3, half-maximal cytotoxic concentration: > 100000 nM
Compound 3 was reported as a limit; the forecaster's own chance of this, stated with the estimate: 25%; middle value at least 3.3-fold (0.52 log units) from the limit.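

In this assay, replacing isopropoxy on the carbonyl carbon with amino gives an at least 5.5-fold higher number from compound 1 to compound 3 (0.74 log units; beyond the scatter), so the carbonyl at this position does not by itself bring a measured cytotoxic concentration. Among the three compounds shown, only the isopropoxycarbonyl compound gives a measured number. Compound 2 and compound 3 both stand at a limit of the assay, not a number, so the step between them cannot be read: the limit of > 100000 nM in this assay, at which 2 of the 3 values shown sit.

As far as these compounds go, it remains open whether a carboxylic acid or a methyl ester at this position would stay at the limit or read close to compound 1.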